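Amide nitrogen substituent change in a paw-edema series

This account rests on a few compounds, and the source may have more. Where it says the series, first, only, none or still open, it means among the compounds named here.

The series shares one core and varies only the group on the amide nitrogen. Compound 1 `CCCNC(=O)CC1CCc2cc(OC)c(OC)cc21` carries propyl there and gives 22.2% in a functional assay on the whole organism (strain Wistar) for inhibition, with Rattus norvegicus as the target, read by paw edema, with stated times of 60 min and 6 h, at a dose of 100 mg/kg by the oral route; a higher number here means more inhibition at the dose given (going by the name of the read-out), a lower number less inhibition. Compound 2 `CCCCNC(=O)CC1CCc2cc(OC)c(OC)cc21` carries butyl and in this assay gives 24.1%; compound 3 `CCCCCCNC(=O)CC1CCc2cc(OC)c(OC)cc21` carries hexyl and in this assay gives 38.3%. The step of a number 1.9 percentage points higher from compound 1 to compound 2 (within the scatter) lies within the scatter, whereas a number 16.1 percentage points higher from compound 1 to compound 3 (beyond the scatter) and a number 14.2 percentage points higher from compound 2 to compound 3 (beyond the scatter) lie beyond it, so compound 3 stands highest of the three, separated from each of the others by more than the scatter.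

Compound 4 `COc1cc2c(cc1OC)C(CC(=O)NC1CCCCC1)CC2` differs from compound 3 by cyclohexyl in place of hexyl on an amide-type nitrogen. Each measured step adds chain carbons to an open-chain substituent on the same nitrogen; none exchanges a chain for a ring, so none bears directly on this change. With the carbon count unchanged, the measured steps give no ground for a large move in either direction; a small downward step inside the scatter is expected, a number 5.3 percentage points lower from compound 3 to compound 4 (within the scatter). Compound 4 is therefore expected to give about 33% in this assay, with a range from 20% to 46%.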

Compound 4, a percentage reported as inhibition, in the whole organism at one dose (the size of the read-out at that dose, not a potency): 48.2%
The estimate for compound 4 lay 15.2 percentage points below the measured number; measured number above the stated range.
By their numbers in this assay, from the lowest: compounds 1 and 2 (each within the scatter of the next); then compounds 3 and 4 (each within the scatter of the next).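

In this assay the exchange of hexyl for cyclohexyl on an amide-type nitrogen, with the carbon count unchanged, gives a number 9.9 percentage points higher from compound 3 to compound 4 (within the scatter); at this position a closed ring and an open chain of this size therefore cannot be told apart. Against the shorter chains the ring shows a number 24.1 percentage points higher from compound 2 to compound 4 (beyond the scatter) and a number 26 percentage points higher from compound 1 to compound 4 (beyond the scatter), which places compounds 3 and 4 together on a level above compounds 1 and 2. Nothing measured here bears on why the ring and the hexyl chain read alike.

Going by these compounds, whether that level holds for a smaller ring such as cyclopentyl, an aromatic ring such as phenyl or a longer chain such as octyl remains open. Also open, on these data alone, is how a ring containing oxygen, such as tetrahydropyranyl, would read at this nitrogen.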